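Branching the acid chain on the isoindolinone nitrogen

The source may hold more compounds than are shown below. What is called first, only, known or untested is meant among the compounds shown, and "the series" means these compounds.

Compound 2 `O=C(O)CCCN1Cc2ccc(NC(=O)c3ccc(C4CCNCC4)cc3)cc2C1=O` carries a 3-carboxypropyl group on the ring amide nitrogen of its core. In a functional assay on a cell-free system (Platelet, plasma, Homo sapiens) for inhibition (a higher number here means a weaker inhibitor, a lower number a stronger inhibitor), compound 2 gives 410000 nM, the highest of the two numbers recorded so far. Its nearest neighbour is compound 1 `O=C(O)CCN1Cc2ccc(NC(=O)c3ccc(C4CCNCC4)cc3)cc2C1=O`, which in this assay gives 9600 nM. For the measured compounds named here, the single step between them, a 43-fold higher number from compound 1 to compound 2 (1.63 log units; beyond the scatter), shows how much the chain length between the ring nitrogen and the carboxylic acid matters.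

Compound 3 `CC(CC(=O)O)N1Cc2ccc(NC(=O)c3ccc(C4CCNCC4)cc3)cc2C1=O` has not yet been measured. 1-(carboxymethyl)ethyl in place of 3-carboxypropyl on an amide-type nitrogen in a ring Compound 3 therefore returns to the two-bond spacing between the ring nitrogen and the carboxylic acid found in compound 1, while keeping the same atom count as compound 2.

Because the step of a 43-fold higher number from compound 1 to compound 2 (1.63 log units; beyond the scatter) was large and ran against the longer chain, a step of similar size in the opposite direction is expected for a 21-fold lower number from compound 2 to compound 3 (1.31 log units; beyond the scatter). Compound 3 is estimated to give 20000 nM in this assay, with a range from 5000 nM to 100000 nM.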

Compound 3, half-maximal inhibitory concentration: 6200 nM
For compound 3 the middle estimate is 3.2-fold (0.51 log units) above the measured one, and the stated range covers the measured number.
By their numbers in this assay, from the lowest: compounds 3 and 1 (each within the scatter of the next); then compound 2.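

The two groups on the amide-type nitrogen in a ring, 3-carboxypropyl and 1-(carboxymethyl)ethyl, hold the same count of heavy atoms, yet a 66-fold lower number from compound 2 to compound 3 (1.82 log units; beyond the scatter) is a large step in this assay. The size of the group therefore does not settle the result at this position, and how its atoms are joined does matter among these compounds. Methyl in place of hydrogen on the saturated chain carbon bound to the amide-type nitrogen in a ring is accommodated, since a 1.5-fold lower number from compound 1 to compound 3 (0.19 log units; within the scatter) lies within the scatter and the two compounds cannot be told apart in this assay. Nothing shown accounts for the large difference between the two isomeric chains.

The compounds shown leave open whether a shorter chain such as carboxymethyl, or a larger branch such as ethyl or a second methyl on the same saturated chain carbon, would keep compound 3 level with compound 1. They also leave open whether the carboxylic acid itself is needed at the end of the chain, as a primary amide or a tetrazole in its place would show.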